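Ester to Pyrrolidine Amide on a Shared Chalcone Core

A few compounds are considered here, and "the series" means these few. Any claim that something is new, unique, unknown or untested is made for them only; others in the source may bear on it.

Compound 1 `CCCOC(=O)c1ccc(/C=C/C(=O)c2cc(OC)ccc2OC)cc1` carries a propoxy group on a carbonyl carbon attached to the aromatic ring. For the measured compounds named here, in a functional assay on PC-3 cells (Homo sapiens) for cytotoxicity, read by MTT assay, with a stated time of 72 h (a higher number here means a weaker inhibitor, a lower number a stronger inhibitor), compound 1 gives 26900 nM, the highest of the two numbers measured so far. Compound 2 `CCCNC(=O)c1ccc(/C=C/C(=O)c2cc(OC)ccc2OC)cc1` differs in one place, with propylamino in place of propoxy on the carbonyl carbon, and in this assay compound 2 gives 1500 nM, a step of an 18-fold lower number from compound 1 to compound 2 (1.25 log units; beyond the scatter). Compound 3 `COc1ccc(OC)c(C(=O)/C=C/c2ccc(C(=O)N3CCCC3)cc2)c1` changes the same position differently: pyrrolidin-1-yl in place of propoxy on a carbonyl carbon. Going by the values given here, the step from compound 1 to compound 2 is the only measured change that bears on this, and it was large. Since compound 3 also replaces the ester oxygen with a nitrogen, though the nitrogen now sits in a ring, a step in the same direction is expected, estimated as a 9.0-fold lower number from compound 1 to compound 3 (0.95 log units; beyond the scatter). For compound 3 the expected value in this assay is 3000 nM, within a range from 800 nM to 12000 nM.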

Compound 3, half-maximal inhibitory concentration: 530 nM
For compound 3 the middle estimate is 5.7-fold (0.75 log units) above the measured one, and the stated range ends above it.
By their numbers in this assay, from the lowest: compound 3; then compound 2; then compound 1.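

The change from propoxy to pyrrolidin-1-yl on the carbonyl carbon gives a 51-fold lower number from compound 1 to compound 3 (1.71 log units; beyond the scatter) in this assay and shows that a second nitrogen-linked group at this position also gives a much lower number than the ester. Going from propylamino to pyrrolidin-1-yl gives a further, modest a 2.8-fold lower number from compound 2 to compound 3 (0.45 log units; beyond the scatter), so a low number here does not need the amide hydrogen that compound 2 carries and compound 3 lacks. Nothing shown here explains why these groups differ in this assay.

The ring and the loss of the amide hydrogen arrive together in compound 3, and an open-chain dipropylamino group on the same carbonyl carbon would help tell them apart. As far as these compounds go, how a six-membered piperidin-1-yl ring or a morpholin-4-yl ring would compare with pyrrolidin-1-yl also remains open.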